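A few compounds are considered here, and "the series" means these few. Any claim that something is new, unique, unknown or untested is made for them only; others in the source may bear on it.

Working notes on the series. Compound 2 `O=C(CN(c1nc(Cl)nc2c1ncn2C1CCCCO1)C1CC1)NCC(=O)OCc1ccccc1` stands highest of the two numbers in a functional assay on the whole organism with Mus musculus as the target, with a stated time of 90 min, at a dose of 25 umol/kg by the oral route (on this read-out lower numbers stand for a weaker effect and higher numbers for a stronger effect at the one dose given), where compound 2 gives 25.9%; the nearest is compound 1 `O=C(CN(c1nc(Cl)nc2c1ncn2C1CCCCO1)C1CC1)N[C@@H](CCC(=O)OCc1ccccc1)C(=O)OCc1ccccc1`, which in this assay gives 25.2%, a gap within the scatter. Among the measured compounds shown here, the only measured step, a number 0.7 percentage points higher from compound 1 to compound 2 (within the scatter), put hydrogen in place of 2-(benzyloxycarbonyl)ethyl on a saturated chain carbon bound to an amide-type nitrogen and a carbonyl carbon. Compound 3 `CC[C@H](C)[C@H](NC(=O)CN(c1nc(Cl)nc2c1ncn2C1CCCCO1)C1CC1)C(=O)OCc1ccccc1` differs from compound 2 by sec-butyl in place of hydrogen on a saturated chain carbon bound to an amide-type nitrogen and a carbonyl carbon, at that same place. That one step is the only one that bears on the change, and it was within the scatter, so the expected step of a number 0.1 percentage points higher from compound 2 to compound 3 (within the scatter) is none beyond the scatter. Compound 3 is therefore expected to give about 26% in this assay, with a range from 14% to 40%.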

Compound 3, a percentage reported as activity, at one dose (the size of the read-out at that dose, not a potency): 22.6%
For compound 3 the middle estimate is 3.4 percentage points above the measured one, and the stated range covers the measured number.
By their numbers in this assay, from the lowest: compounds 3, 1 and 2 (each within the scatter of the next).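

In this assay, sec-butyl in place of hydrogen on a saturated chain carbon bound to an amide-type nitrogen and a carbonyl carbon gives a number 3.3 percentage points lower from compound 2 to compound 3 (within the scatter), so adding a group of four carbons with no ring at this place leaves the read-out within the scatter. Exchanging the two larger groups gives a number 2.6 percentage points lower from compound 1 to compound 3 (within the scatter), so hydrogen, 2-(benzyloxycarbonyl)ethyl and sec-butyl all now read alike at this place, and the ester in the 2-(benzyloxycarbonyl)ethyl chain shows no separate effect here. Nothing available gives a reason for this flat result.

Going by these compounds, it remains open whether an amine, a carboxylic acid or a phenyl ring at this place would give a step beyond the scatter. With one dose only, these numbers show the size of the effect at that dose and nothing more.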